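Urea analogues on a pyrazole scaffold: a single halogen swap

The source may hold more compounds than are shown below. What is called first, only, known or untested is meant among the compounds shown, and "the series" means these compounds.

Compound 1 `O=C(Nc1cccc(-n2cc(-c3ccncc3)c(-c3cc(O)cc(Cl)c3)n2)c1)Nc1ccc(Cl)c(Cl)c1`: 90%
Compound 2 `COc1cc(Cl)cc(-c2nn(-c3cccc(NC(=O)Nc4ccc(Cl)c(C(F)(F)F)c4)c3)cc2-c2ccncc2)c1`: 64%

In a functional assay on DU-145 cells (Homo sapiens) for inhibition, read by sulforhodamine B assay, with a stated time of 48 h, tested at 1 uM (on this read-out lower numbers stand for a stronger effect and higher numbers for a weaker effect at the one concentration tested), compound 2 gives 64%, the lower of the two numbers shown and thus the stronger effect; compound 1 gives 90%, a difference beyond the usual scatter. Compound 3 `COc1cc(Cl)cc(-c2nn(-c3cccc(NC(=O)Nc4ccc(Cl)c(Cl)c4)c3)cc2-c2ccncc2)c1` differs from compound 2 in one place: chloro in place of trifluoromethyl on an aromatic carbon. For the measured compounds named here, no measured pair isolates this change, so the expectation rests on the two values above. Because compound 1, which also carries the dichlorophenyl urea, gives 90%, the step of a number 14 percentage points higher from compound 2 to compound 3 (beyond the scatter) is expected to move toward a higher number, modestly. Compound 3 is therefore estimated at 78%, within 58% to 95%.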

Compound 3, a percentage reported as activity, at one concentration (the size of the read-out at that concentration, not a potency): 93%
Beside the measured number, compound 3's estimate is 15 percentage points below it; measured number inside the range.
By their numbers in this assay, from the lowest: compound 2; then compounds 1 and 3 (each within the scatter of the next).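

In this assay, chloro in place of trifluoromethyl on this aromatic carbon, ortho to a chloro group, now has a measured size: a number 29 percentage points higher from compound 2 to compound 3 (beyond the scatter). With the 3,4-dichlorophenyl urea held constant, methyl in place of hydrogen on the oxygen gives a number 3 percentage points higher from compound 1 to compound 3 (within the scatter), so that change does not separate these two compounds. Nothing shown explains the step from trifluoromethyl to chloro.

The compounds shown leave open whether trifluoromethyl gives the same step when the oxygen carries hydrogen rather than methyl. They also leave open how a nitrile or an amine would read on this aromatic carbon.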